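Swapping dimethylphenyl for dichlorophenyl on a sulfonamide

A few compounds are considered here, and "the series" means these few. Any claim that something is new, unique, unknown or untested is made for them only; others in the source may bear on it.

Of the compounds shown here, three have so far been tested in an ADME assay on HCT-116 cells (Homo sapiens) for cytotoxicity, read by CellTiter-Glo, with a stated time of 72 h (a lower number here means a stronger inhibitor, a higher number a weaker inhibitor), and none of them produced a numeric result. Compound 1 `CC1CCN(C2CCN(S(=O)(=O)c3cn(C)c(=O)n(C)c3=O)CC2)CC1` stopped at a limit of the assay, > 10000 nM, which is a limit and not a number. Compound 2 `Cc1ccc(S(=O)(=O)N2CCC(N3CCC(C)CC3)CC2)cc1C` likewise stopped at a limit, > 5000 nM. Compound 3 `CC1CCN(C2CCN(C(=O)c3ccc(OC(F)(F)F)cc3)CC2)CC1` also gave only a limit, > 5000 nM. Compound 2 therefore stands where the other two stand: with a limit rather than a measured value, and the two further values shown are limits as well.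

Against this background comes compound 4 `CC1CCN(C2CCN(S(=O)(=O)c3cc(Cl)cc(Cl)c3)CC2)CC1`, not yet measured. It differs from compound 2 in a single place: 3,5-dichlorophenyl in place of 3,4-dimethylphenyl on a sulfonyl sulfur. The shared core and the sulfonamide stay as they are; only the aromatic group on the sulfonyl sulfur changes.

For the measured compounds named here, since every value sits at a limit, as the limit of > 10000 nM in this assay, at which 1 of the 3 values shown sits, and the limit of > 5000 nM in this assay, at which 2 of the 3 values shown sit, show, there is no measured step to lean on. The expected step for compound 4 is a step that the limit leaves unreadable from compound 2 to compound 4, that is, no movement beyond the scatter. Compound 4 is thus estimated at 10000 nM, within a range from 4000 nM to 30000 nM, and the assay is expected most likely to report only a limit again.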

Compound 4, half-maximal inhibitory concentration: > 5000 nM
Compound 4: a limit, no number (the forecaster's own chance of this, stated with the estimate: 75%); the middle value does not contradict the limit.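

In this assay compound 4 gives > 5000 nM as a limit and not a number. For the compounds shown here, compound 2 likewise gives > 5000 nM as a limit, so no step between compound 2 and compound 4 can be read. The compounds shown leave open whether 3,5-dichlorophenyl in place of 3,4-dimethylphenyl on a sulfonyl sulfur changes cytotoxicity at all.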